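This account rests on a few compounds, and the source may have more. Where it says the series, first, only, none or still open, it means among the compounds named here.

Measured so far in a functional assay on DU-145 cells (Homo sapiens) for antiproliferative activity, read by sulforhodamine B assay, with a stated time of 72 h; a lower number here means a stronger inhibitor of growth, a higher number a weaker inhibitor of growth:

Compound 1, `CCc1cc(=O)c2ccc(OCc3ccccc3)c(C)c2o1`, gives 27700 nM.
Compound 2, `CCc1oc2c(C)c(OC)ccc2c(=O)c1Br`, gives only a limit, > 33600 nM.
Compound 3, `CCc1oc2c(C)c(OC(C)C)ccc2c(=O)c1Br`, gives only a limit, > 30700 nM.

Compound 3 thus stands at a limit of this assay, not at a number: its growth inhibition was too weak to be measured within the tested range. The same holds for compound 2, so the step that the two limits leave unreadable from compound 2 to compound 3 cannot be read, because both ends sit at limits, the limit of > 33600 nM in this assay, at which 1 of the 3 values shown sits, and (the limit of > 30700 nM in this assay, at which 1 of the 3 values shown sits). Only compound 1, which carries a benzyl group on the ring oxygen but no bromine, gives a real number, and that number is a weak one.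

Compound 4, `CCc1oc2c(C)c(OCc3ccccc3)ccc2c(=O)c1Br`, differs from compound 3 in one place: benzyl in place of isopropyl on an oxygen on an aromatic ring. Within the data shown here, no measured step bears directly on this change, since the only step among the measured compounds is unreadable. The value of compound 1 suggests that a benzyl ether on this core gives at best weak growth inhibition. For compound 4 the step of an at least 1.0-fold lower number from compound 3 to compound 4 (0.01 log units; that floor lies within the scatter) is therefore expected to be small or none beyond the scatter, with a good chance that the assay reports a limit again. Compound 4 is estimated at 30000 nM, in a range from 10000 nM to 90000 nM.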

Compound 4, concentration for 50% growth inhibition: > 26700 nM
Compound 4: no number, only a limit (the forecaster's own chance of this, stated with the estimate: 60%); the middle value lies beyond the limit too.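

In this assay compound 4 gives > 26700 nM, which is a limit and not a number. The steps to compound 4 from compound 1, compound 2 and compound 3 cannot be read. The compounds shown leave open how strongly compound 2, compound 3 and compound 4 inhibit growth, and whether bromo in place of hydrogen on an aromatic carbon changes growth inhibition at all.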